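Lengthening the hydroxyalkyl chain on a vitamin D receptor ligand

The compounds below may be only part of what the source reports. "The series", "measured", "known", "first", "only" and "open" are said of these compounds alone.

Three analogues built on a shared core carry a hydroxyalkoxy chain on one aromatic ring. In an assay on cells for binding affinity to vitamin D3 receptor (Homo sapiens), read by fluorescence, tested at 1 uM (a lower number here means less inhibition, a higher number more inhibition at the concentration tested (going by the name of the read-out)), compound 1 `CCC(CC)(c1ccc(OCCCO)c(C)c1)c1ccc(OCC(O)C(C)(C)C)c(OCC(O)C(C)(C)C)c1` gives 76%, compound 2 `CCC(CC)(c1ccc(OCCCCO)c(C)c1)c1ccc(OCC(O)C(C)(C)C)c(OCC(O)C(C)(C)C)c1` gives 71%, and compound 3 `CCC(CC)(c1ccc(OCCCCCCO)c(C)c1)c1ccc(OCC(O)C(C)(C)C)c(OCC(O)C(C)(C)C)c1` gives 52%. The change hydroxymethyl in place of hydroxy on a saturated chain carbon, three bonds along the chain from an oxygen on an aromatic ring produced a number 5 percentage points lower from compound 1 to compound 2 (within the scatter), whereas 3-hydroxypropyl in place of hydroxy on a saturated chain carbon, three bonds along the chain from an oxygen on an aromatic ring produced a number 24 percentage points lower from compound 1 to compound 3 (beyond the scatter) and a number 19 percentage points lower from compound 2 to compound 3 (beyond the scatter). Compound 4 `CCC(CC)(c1ccc(OCCCCCCCO)c(C)c1)c1ccc(OCC(O)C(C)(C)C)c(OCC(O)C(C)(C)C)c1` carries the same kind of change as compound 2 did, (hydroxymethyl in place of hydroxy on a saturated chain carbon, six bonds along the chain from an oxygen on an aromatic ring), but six bonds rather than three bonds along the chain from the aromatic oxygen. Compound 4 is expected to give 44% because a number 19 percentage points lower from compound 2 to compound 3 (beyond the scatter) fell beyond the scatter as the chain lengthened, although the first lengthening did not. That means an expected a number 8 percentage points lower from compound 3 to compound 4 (within the scatter) in this assay.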

Compound 4, a percentage reported as inhibition, at one concentration (the size of the read-out at that concentration, not a potency): 5%
Compound 4: the middle estimate sits 39 percentage points above what was measured; measured number outside the range, below it.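

In this assay the longest chain shown gives a number 47 percentage points lower from compound 3 to compound 4 (beyond the scatter), a number 66 percentage points lower from compound 2 to compound 4 (beyond the scatter) and a number 71 percentage points lower from compound 1 to compound 4 (beyond the scatter), and the size of one added hydroxymethyl does not carry over from a shorter chain to a longer one: the same change on two cores in this assay, a number 5 percentage points lower (within the scatter) from compound 1 to compound 2 and a number 47 percentage points lower (beyond the scatter) from compound 3 to compound 4, 42 percentage points apart, beyond the scatter of two such steps

The larger replacement behaves in the same way, with its step depending on the chain it is made on: the same change on two cores in this assay, a number 24 percentage points lower (beyond the scatter) from compound 1 to compound 3 and a number 66 percentage points lower (beyond the scatter) from compound 2 to compound 4, 42 percentage points apart, beyond the scatter of two such steps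

These compounds show that a step measured on one chain length cannot simply be transferred to another in this series, but they do not show why the steps differ, or whether the same would hold on a different core.

They leave open what a still longer chain would give. They also leave open whether an amine or a carboxylic acid at the chain end, in place of hydroxy, would follow the same course.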